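A few compounds are considered here, and "the series" means these few. Any claim that something is new, unique, unknown or untested is made for them only; others in the source may bear on it.

Compound 1 `CN1CCN(c2ccc(Nc3nccc(-c4ccc5ccccc5c4)n3)cc2C(F)(F)F)CC1` gives 3040 nM in a toxicity assay on THP-1 cells (Homo sapiens) for cytotoxicity, read by luminescence and CellTiter-Glo, with a stated time of 72 h; a higher number here means that more compound is tolerated, a lower number that less compound is tolerated.
Compound 2 `CN1CCN(c2ccc(Nc3nccc(-c4cccc([N+](=O)[O-])c4)n3)cc2C(F)(F)F)CC1` gives 3890 nM in this assay.
Compound 3 `CN1CCN(c2ccc(Nc3nccc(-c4ccccc4)n3)cc2C(F)(F)F)CC1` gives 4100 nM in this assay.

Of the compounds shown here, three sharing one core have been measured in this assay, and their numbers sit close together. Compound 2 stands second highest of the three: its nearest neighbour is compound 3, its furthest is compound 1, and both of those gaps lie within the scatter. The measured steps confirm this: a 1.3-fold higher number from compound 1 to compound 2 (0.11 log units; within the scatter), a 1.3-fold higher number from compound 1 to compound 3 (0.13 log units; within the scatter) and a 1.1-fold higher number from compound 2 to compound 3 (0.02 log units; within the scatter) are all within the scatter, so exchanging the aromatic group on the core of compound 1 for a nitro-bearing phenyl or for a plain phenyl has left the half-maximal cytotoxic concentration essentially unchanged.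

The next compound, compound 4 `CN1CCN(c2ccc(Nc3nccc(-c4cccnc4)n3)cc2C(F)(F)F)CC1`, departs from compound 2 in that same position: pyridin-3-yl in place of 3-nitrophenyl on an aromatic carbon. The step from compound 2 to compound 3 bears most directly on this change, since it also removes the nitro group, and it was within the scatter; the steps from compound 1 likewise showed no movement. Compound 4 is therefore expected to show no step beyond the scatter in this assay, that is a 1.0-fold higher number from compound 2 to compound 4 (0.01 log units; within the scatter). The estimate for compound 4 is 4000 nM, with a range from 2000 nM to 8000 nM.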

Compound 4, half-maximal cytotoxic concentration: 1060 nM
For compound 4 the middle estimate is 3.8-fold (0.58 log units) above the measured one, and the stated range ends above it.
By their numbers in this assay, from the lowest: compound 4; then compounds 1, 2 and 3 (each within the scatter of the next).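

Going by these compounds alone, at this position the exchange of groups on the shared core does move the number in this assay, which the earlier compounds never showed: pyridin-3-yl gives a 3.7-fold lower number from compound 2 to compound 4 (0.56 log units; beyond the scatter) and a 3.9-fold lower number from compound 3 to compound 4 (0.59 log units; beyond the scatter) and also a 2.9-fold lower number from compound 1 to compound 4 (0.46 log units; beyond the scatter) in the comparison with the largest group. The step from phenyl is the plainest of these, since the two groups differ only in that one ring carbon is replaced by a nitrogen, whereas adding a nitro group or going to naphthalen-2-yl had left the number within the scatter, so among these four compounds only the one with a hetero atom in this ring stands apart, with less compound tolerated than for any of the other three. No measurement is at hand that explains this drop.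

A single pyridine cannot show whether the step belongs to the ring nitrogen as such or to where it sits in the ring, a question that pyridin-4-yl or pyridin-2-yl at the same position would address. As far as these compounds go, it also remains open whether a nitrogen carried outside the ring, as in a 3-aminophenyl group, would lower the number in this assay in the same way.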